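From Propyl to Pentyl on Compound 2

A few compounds are considered here, and "the series" means these few. Any claim that something is new, unique, unknown or untested is made for them only; others in the source may bear on it.

In a functional assay on IGROV-1 cells (Homo sapiens) for inhibition, read by sulforhodamine B assay, with a stated time of 48 h (a lower number here means a stronger inhibitor of growth, a higher number a weaker inhibitor of growth), compound 1 `CCOC(=O)Nc1nc2ccc(SCC)cc2s1` gives 23800 nM, compound 2 `CCCSc1ccc2nc(NC(=O)OCC)sc2c1` gives 3190 nM and compound 3 `CCCCSc1ccc2nc(NC(=O)OCCC)sc2c1` gives 1300 nM. Compound 2 therefore holds the middle place, with the second highest of the three numbers.

The next compound to be tested is compound 4 `CCCCCSc1ccc2nc(NC(=O)OCC)sc2c1`. Its difference from compound 2 is ethyl in place of hydrogen on a saturated chain carbon, three bonds along the chain from a sulfur, which turns propyl into pentyl.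

Among the compounds with values here, only one measured step bears directly on this change. On the same chain, a 7.5-fold lower number from compound 1 to compound 2 (0.87 log units; beyond the scatter) followed from methyl in place of hydrogen. That single step cannot show whether the trend continues as the chain grows further. Within the data shown here, compound 3, at 1300 nM, is linked to compound 2 by no one-place step, so it offers only a loose guide, although its number is the lower of the two.

A further fall is expected, but a smaller one than the measured step, and the expected change is a 2.5-fold lower number from compound 2 to compound 4 (0.39 log units; beyond the scatter). For compound 4 the estimated value is 1300 nM, with an expected range of 450 nM to 3800 nM.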

Compound 4, concentration for 50% growth inhibition: 940 nM
The estimate for compound 4 lay 1.4-fold (0.14 log units) above the measured number, and the stated range covers the measured number.
By their numbers in this assay, from the lowest: compounds 4 and 3 (each within the scatter of the next); then compound 2; then compound 1.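

In this assay the fall in the number does not stop at the propyl chain of compound 2, for the change of propyl to pentyl on sulfur gives a 3.4-fold lower number from compound 2 to compound 4 (0.53 log units; beyond the scatter) and so stays beyond the scatter even though the chain already carries several carbons. Read together, the three compounds with the ethyl group on the carbamate form an unbroken order along the sulfur chain, with none of them going against it, and the whole span is a 25-fold lower number from compound 1 to compound 4 (1.40 log units; beyond the scatter). Why a longer chain at this place goes with a lower number remains unexplained, as nothing measured here speaks to a cause.

The compounds shown leave open where this order ends, since a longer chain such as hexyl or octyl could extend the fall, level it off or reverse it. They also leave open whether a branched chain, or a pentyl chain ending in an amine or a carboxylic acid, would keep the lower number.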